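Methyl in place of methoxy, tested for cytotoxicity

The source may hold more compounds than are shown below. What is called first, only, known or untested is meant among the compounds shown, and "the series" means these compounds.

Compound 1 `COc1ccc2nc(NC(=O)c3cn(-c4ccccc4)nc3-c3ccccc3)sc2c1` and compound 2 `Cc1ccc2nc(NC(=O)c3cn(-c4ccccc4)nc3-c3ccccc3)sc2c1` share one core and differ by methyl in place of methoxy on an aromatic carbon. In an ADME assay on HEK-293T cells (Homo sapiens) for cytotoxicity, read by MTT assay, with a stated time of 72 h (on this read-out higher numbers stand for weaker inhibition and lower numbers for stronger inhibition), compound 1 gives > 50000 nM, which is a limit of the assay and not a number. Compound 2 likewise gives > 50000 nM, again a limit. The step that the two limits leave unreadable from compound 1 to compound 2 rests on (the limit of > 50000 nM in this assay, at which 2 of the 3 values shown sit). For the measured compounds named here, compound 3 `COc1ccc2nc(NC(=O)c3cn(-c4ccccc4)nc3-c3ccc(Cl)cc3)sc2c1` differs from compound 1 by chloro in place of hydrogen on an aromatic carbon; in this assay compound 3 gives 29600 nM, the only plain number among the three, and the step of an at least 1.6-fold lower number from compound 1 to compound 3 (0.22 log units; that floor lies within the scatter) follows. Compound 4 `Cc1ccc2nc(NC(=O)c3cn(-c4ccccc4)nc3-c3ccc(Cl)cc3)sc2c1` stands to compound 3 exactly as compound 2 stands to compound 1, the same change (methyl in place of methoxy on an aromatic carbon). For compound 4 a step of about a 1.2-fold higher number from compound 3 to compound 4 (0.07 log units; within the scatter) is expected, because the matching step that the two limits leave unreadable from compound 1 to compound 2 gave no readable size. Compound 4 is therefore estimated at 35000 nM, within a range from 15000 nM to 100000 nM.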

Compound 4, half-maximal inhibitory concentration: 35600 nM
The estimate for compound 4 lay 1.0-fold (0.01 log units) below the measured number; measured number inside the range.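

In this assay, methyl in place of methoxy on the chlorinated core gives a 1.2-fold higher number from compound 3 to compound 4 (0.08 log units; within the scatter), so this change can be read on that core only. Chloro in place of hydrogen gives an at least 1.4-fold lower number from compound 2 to compound 4 (0.14 log units; that floor lies within the scatter), and this floor can be set beside the earlier one only as a floor, which does not show that the change carries over with the same size: the same change on two cores in this assay, an at least 1.6-fold lower number (0.22 log units; that floor lies within the scatter) from compound 1 to compound 3 and an at least 1.4-fold lower number (0.14 log units; that floor lies within the scatter) from compound 2 to compound 4; the limit leaves it open whether they differ. The steps that have limits at both ends cannot be read, so the data do not show whether methyl in place of methoxy behaves alike on the two cores: the limit of > 50000 nM in this assay, at which 2 of the 4 values shown sit.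

The compounds shown leave open what an amine or a carboxylic acid would give on that aromatic carbon in this assay. From the compounds shown here alone, a longer chain there also remains open.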